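Swapping the methoxy on a saturated ring for a hydroxyl

The compounds below may be only part of what the source reports. "The series", "measured", "known", "first", "only" and "open" are said of these compounds alone.

Compound 1, with structure `CO[C@H]1CC[C@@H](Nc2cc(NCc3cnccc3C(F)(F)F)ncc2C#N)CC1`, is the weakest of the three measured compounds in an assay on isolated protein for inhibition of protein kinase C delta type (Homo sapiens), read by TR-FRET, with a stated time of 2 h; a lower number here means a stronger inhibitor, a higher number a weaker inhibitor: compound 1 gives 5000 nM, the highest number of the set. Compound 2 `CN(C)C(=O)[C@H]1CC[C@@H](Nc2cc(NCc3cnccc3C(F)(F)F)ncc2C#N)CC1` gives 1800 nM, and compound 3 `N#Cc1cnc(NCc2cnccc2C(F)(F)F)cc1N[C@H]1CC[C@@H](c2nc[nH]n2)CC1` gives 1200 nM. The steps away from compound 1 both improve the number: a 2.8-fold lower number from compound 1 to compound 2 (0.44 log units; beyond the scatter) and a 4.2-fold lower number from compound 1 to compound 3 (0.62 log units; beyond the scatter), while the pair of compounds 2 and 3 differ only within the scatter, a 1.5-fold lower number from compound 2 to compound 3 (0.18 log units; within the scatter).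

Compound 4 `CC1(C)C[C@@H](Nc2cc(NCc3cnccc3C(F)(F)F)ncc2C#N)CC[C@H]1O` changes compound 1 in one place: 4-hydroxy-3,3-dimethylcyclohexyl in place of 4-methoxycyclohexyl on a nitrogen on an aromatic ring. The two measured steps bear on this change, since each also replaces the methoxy on the saturated ring, and each gave a modest gain. The new group brings a hydrogen-bond donor, as the 1H-1,2,4-triazol-3-yl of compound 3 does, so a modest improvement is expected rather than a loss. The estimate for compound 4 is 2500 nM, with a range from 1000 nM to 6000 nM, which means an expected step of a 2.0-fold lower number from compound 1 to compound 4 (0.30 log units; within the scatter).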

Compound 4, half-maximal inhibitory concentration: 2400 nM
For compound 4 the middle estimate is 1.0-fold (0.02 log units) above the measured one; the range from low to high includes it.
By their numbers in this assay, from the lowest: compounds 3, 2 and 4 (each within the scatter of the next); then compound 1.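

In this assay, 4-hydroxy-3,3-dimethylcyclohexyl gives a 2.1-fold lower number from compound 1 to compound 4 (0.32 log units; beyond the scatter) and so shows that a modest gain can also come from changing the cyclohexyl ring itself, whereas compounds 2 and 3 replace only the methoxy. All three replacements now give lower numbers than compound 1, even though the groups that enter are quite different. This step combines two differences, a hydroxyl in place of the methoxy and two added methyl groups on the ring, and nothing measured here separates their contributions or explains the gain.

The plain 4-hydroxycyclohexyl group, carrying the hydroxyl without the two methyl groups, would show how much of the step belongs to each difference. On these data alone, it also remains open how an amine or a carboxylic acid in place of the methoxy would compare.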